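Swapping a methoxy for a dimethylamino on the same scaffold

The source may hold more compounds than are shown below. What is called first, only, known or untested is meant among the compounds shown, and "the series" means these compounds.

Of the compounds shown here, two have been measured in a functional assay on aorta (strain Wistar) for inhibition, with Thoracic aorta (Rattus norvegicus) as the target; on this read-out lower numbers stand for stronger inhibition and higher numbers for weaker inhibition. Compound 1 `CCOc1nc(-c2cc3ccccc3o2)cc(-c2cccc3ccccc23)c1C#N` gives 344000 nM in this assay, and compound 2 `CCOc1nc(-c2cc3ccccc3o2)cc(-c2ccc(OC)cc2)c1C#N` gives 204000 nM. For the measured compounds named here, the only step between them, a 1.7-fold lower number from compound 1 to compound 2 (0.23 log units; within the scatter), is within the scatter, so the two numbers cannot be told apart, and compound 2 is simply the lower of the two numbers rather than a stronger inhibitor.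

Compound 3 `CCOc1nc(-c2cc3ccccc3o2)cc(-c2ccc(N(C)C)cc2)c1C#N` differs from compound 2 by dimethylamino in place of methoxy on an aromatic carbon. Going by the values given here, no measured step touches this position: the one step recorded concerns a different part of the molecule and was itself within the scatter. Nothing in the data therefore argues for a change beyond the scatter in this assay. Compound 3 is expected to give about 180000 nM, within a range of 60000 nM to 540000 nM. This estimate means a step of a 1.1-fold lower number from compound 2 to compound 3 (0.05 log units; within the scatter), expected to stay within the scatter.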

Compound 3, half-maximal inhibitory concentration: 338000 nM
Beside the measured number, compound 3's estimate is 1.9-fold (0.27 log units) below it, within the range that was stated.
By their numbers in this assay, from the lowest: compounds 2, 3 and 1 (each within the scatter of the next).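

In this assay, dimethylamino in place of methoxy on this aromatic carbon gives a 1.7-fold higher number from compound 2 to compound 3 (0.22 log units; within the scatter), so the first direct test at this position shows no difference that can be read. The larger swap of naphthalen-1-yl for 4-(dimethylamino)phenyl gives a 1.0-fold lower number from compound 1 to compound 3 (0.01 log units; within the scatter), so this change also stays within the scatter, and neither of these two new steps separates the compounds. There is no independent evidence here that could bear on this result.

On these data alone, it remains open whether a carboxylic acid or a primary amine in place of the methoxy would give a step beyond the scatter. All three compounds also share the same core, so what a change elsewhere in that core would do remains an open question.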